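Arylamino for Piperazinyl: Two Limits and an Open Question

A few compounds are considered here, and "the series" means these few. Any claim that something is new, unique, unknown or untested is made for them only; others in the source may bear on it.

Compound 1 `COc1cc(/C=C/c2nc(NC3CC3)c3sccc3n2)cc(OC)c1OC` and compound 2 `CCN1CCN(c2nc(/C=C/c3cc(OC)c(OC)c(OC)c3)nc3ccsc23)CC1` share one core and differ only at a single aromatic carbon. In a functional assay on L02 cells (Homo sapiens) for inhibition, read by Griess assay, with stated times of 1 h and 24 h (a lower number here means a stronger inhibitor, a higher number a weaker inhibitor), compound 1 gives > 1000000 nM, which is a limit of the assay rather than a number. In this assay compound 2 likewise gives > 1000000 nM, again a limit and not a measured value. The step that the two limits leave unreadable from compound 1 to compound 2 therefore cannot be read, as both of its ends sit at the limit of > 1000000 nM in this assay, at which 2 of the 2 values shown sit. Compound 3 `COc1cc(/C=C/c2nc(Nc3ccc(C)cc3)c3sccc3n2)cc(OC)c1OC` is the next member of the set: (4-methylphenyl)amino in place of 4-ethylpiperazin-1-yl on an aromatic carbon. Going by the values given here, the one measured step touches the same position but is unreadable in both size and direction, so it offers no guide to how compound 3 should behave in this assay. With both known values at the limit, compound 3 is expected to remain there as well, a step of a number no higher from compound 2 to compound 3 (the limit leaves the size open) estimated to stay within the scatter. The estimate for compound 3 in this assay is 1000000 nM, between 100000 nM and 3000000 nM.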

Compound 3, half-maximal inhibitory concentration: < 40000 nM
Compound 3 was reported as a limit; the forecaster's own chance of this, stated with the estimate: 75%; middle value at least 25-fold (1.39 log units) from the limit.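

In this assay this aromatic carbon proves able to shift the read-out after all: (4-methylphenyl)amino in place of 4-ethylpiperazin-1-yl brings an at least 25-fold lower number from compound 2 to compound 3 (1.39 log units; beyond the scatter), and 4-methylphenyl in place of cyclopropyl on the nitrogen brings an at least 25-fold lower number from compound 1 to compound 3 (1.39 log units; beyond the scatter). Compound 1 already carries an amino nitrogen at this carbon, so the nitrogen alone is not enough, and the change that goes with the stronger inhibition here is the 4-methylphenyl group on it. The value of compound 3 is itself a limit and not a number: the limit of < 40000 nM in this assay, at which 1 of the 3 values shown sits.

On these data alone, how far the true value of compound 3 lies past that limit stays open, and the step between compound 1 and compound 2 still cannot be read. Whether the effect needs the methyl group, or would persist with plain phenylamino or a 4-chlorophenylamino group, is also left open.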